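Carboxymethoxy acid series: chloro entering at compound 3

A few compounds are considered here, and "the series" means these few. Any claim that something is new, unique, unknown or untested is made for them only; others in the source may bear on it.

Numbers in an assay on HeLa cells for displacement of a labelled ligand from thyroid hormone receptor alpha (Homo sapiens); a lower number here means a stronger inhibitor, a higher number a weaker inhibitor:
compound 1 `CC(C)c1cc(Cn2ccc3cc(OCC(=O)O)ccc32)ccc1O`: 13.5 nM
compound 2 `Cc1cc2cc(OCC(=O)O)ccc2n1Cc1ccc(O)c(C(C)C)c1`: 16.3 nM

Compound 2 sits alongside compound 1, the step of a 1.2-fold higher number from compound 1 to compound 2 (0.08 log units; within the scatter) lying within the scatter. Compound 3 `Cc1cc2cc(OCC(=O)O)cc(Cl)c2n1Cc1ccc(O)c(C(C)C)c1` differs from compound 2 by chloro in place of hydrogen on an aromatic carbon. For the measured compounds named here, no measured step involves a chloro; the only step available, a 1.2-fold higher number from compound 1 to compound 2 (0.08 log units; within the scatter), concerns a methyl elsewhere and is within the scatter, so it gives no direction for compound 3. No step beyond the scatter is expected in this assay; the estimated step is a 1.1-fold lower number from compound 2 to compound 3 (0.04 log units; within the scatter). Compound 3 is expected to give 15 nM, with a range from 6 nM to 40 nM.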

Compound 3, inhibition constant: 0.38 nM
Compound 3: the middle estimate sits 39-fold (1.60 log units) above what was measured, and the stated range ends above it.
By their numbers in this assay, from the lowest: compound 3; then compounds 1 and 2 (each within the scatter of the next).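

In this assay, chloro in place of hydrogen on this aromatic carbon, ortho to a fused ring and meta to a carboxymethoxy group, gives a 43-fold lower number from compound 2 to compound 3 (1.63 log units; beyond the scatter), whereas the methyl change gave only a 1.2-fold higher number from compound 1 to compound 2 (0.08 log units; within the scatter). The shared core therefore has a position where one heavy atom moves the number far beyond the scatter, which the earlier pair did not reveal. Nothing available gives a reason for this step. From the compounds shown here alone, whether fluoro, bromo or methoxy on this carbon would match chloro remains open, as does whether chloro would give a similar step on the core of compound 1, without the methyl.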